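This account rests on a few compounds, and the source may have more. Where it says the series, first, only, none or still open, it means among the compounds named here.

Compound 1 `C1=NCC(CC2=Cc3ccccc3CC2)N1` and compound 3 `C1=NCC(CC2Cc3ccccc3C2)N1` share the same imidazoline side chain on two related cores; how the two cores differ is not broken down here. In a functional assay for binding affinity to Norepinephrine transporter (Rattus norvegicus), read by radioligand binding, in the presence of a further agent that is not named here (on this read-out higher numbers stand for weaker inhibition and lower numbers for stronger inhibition), compound 1 gives 50.1 nM, and in this assay compound 3 gives 39.8 nM, a gap that lies within the usual scatter of such measurements. Compound 2 `Fc1cccc2c1C=C(CC1CN=CN1)CC2` carries the change fluoro in place of hydrogen on an aromatic carbon on the core of compound 1; in this assay compound 2 gives 126 nM, and the step of a 2.5-fold higher number from compound 1 to compound 2 (0.40 log units; beyond the scatter). Compound 4 `Fc1cccc2c1CC(CC1CN=CN1)C2` has not yet been measured. It carries the change fluoro in place of hydrogen on an aromatic carbon on the core of compound 3, the same change as the one already seen, and among these compounds it occurs twice in all. Because of a 2.5-fold higher number from compound 1 to compound 2 (0.40 log units; beyond the scatter), a step of similar size is expected in this assay, namely a 2.5-fold higher number from compound 3 to compound 4 (0.40 log units; beyond the scatter), although a single measured case leaves room for the step to turn out smaller or larger. Compound 4 is therefore estimated at 100 nM in this assay, with a likely range from 50 nM to 200 nM.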

Compound 4, inhibition constant: 100 nM
Beside the measured number, compound 4's estimate shows no gap at the digits printed; measured number inside the range.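

In this assay, fluoro in place of hydrogen on an aromatic carbon gives a 2.5-fold higher number from compound 3 to compound 4 (0.40 log units; beyond the scatter), so inhibition is weaker after the change, as it was on the core of compound 1. Set side by side, the two steps match: the same change on two cores in this assay, a 2.5-fold higher number (0.40 log units; beyond the scatter) from compound 1 to compound 2 and a 2.5-fold higher number (0.40 log units; beyond the scatter) from compound 3 to compound 4, 1.0-fold (0.00 log units) apart, within the scatter of two such steps. This shows that the size of the step carried over between these two related cores in this one assay, but two pairs are a small sample and do not show how the change would behave on any other core, nor why the number moves.

The compounds shown also leave open whether the step depends on fluoro itself or on its place on the ring, since fluoro appears at only one place on each core. How a chlorine atom, a methoxy group or a nitrile would compare at that same place, or fluoro on another aromatic carbon, remains an open question.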